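The source may report more compounds than this note shows. Statements on the series, on what has been measured and on what is new or still open speak of the compounds shown alone.

In a functional assay (aorta) for antagonist activity, with Oryctolagus cuniculus as the target (a lower number here means a stronger inhibitor, a higher number a weaker inhibitor), compound 1 `CCCCc1ccc(CN)c(=O)n1Cc1ccc(-c2ccccc2-c2nn[nH]n2)cc1` gives 20 nM, the highest of the three numbers measured. Compound 2 `CCCCc1ccc(CNCc2ccccc2)c(=O)n1Cc1ccc(-c2ccccc2-c2nn[nH]n2)cc1` gives 1 nM, and compound 3 `CCCCc1ccc(CN(Cc2ccccc2)C(C)=O)c(=O)n1Cc1ccc(-c2ccccc2-c2nn[nH]n2)cc1` gives 1 nM. The step of a 20-fold lower number from compound 1 to compound 2 (1.30 log units; beyond the scatter) and the step of a 20-fold lower number from compound 1 to compound 3 (1.30 log units; beyond the scatter) were both large, while no change at the digits printed from compound 2 to compound 3 (within the scatter). Compound 4 `CCCCc1cccc(=O)n1Cc1ccc(-c2ccccc2-c2nn[nH]n2)cc1` differs from compound 1 by hydrogen in place of aminomethyl on an aromatic carbon. Going by the values given here, no measured step removes this group; the steps that bear on it only build on it, and with each of those additions the number fell sharply. Taking the group away entirely is therefore expected to move the number the other way, so for compound 4 a value of 100 nM is estimated, within the range 20 nM to 500 nM, which means a 5.0-fold higher number from compound 1 to compound 4 (0.70 log units; beyond the scatter).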

Compound 4, half-maximal inhibitory concentration: 4 nM
For compound 4 the middle estimate is 25-fold (1.40 log units) above the measured one; the whole stated range lies above it.
By their numbers in this assay, from the lowest: compounds 2 and 3 (each within the scatter of the next); then compound 4; then compound 1.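

In this assay, putting hydrogen in place of aminomethyl gives a 5.0-fold lower number from compound 1 to compound 4 (0.70 log units; beyond the scatter) and so the small group raises the number rather than lowering it. The larger groups do better than hydrogen, as a 4.0-fold higher number from compound 2 to compound 4 (0.60 log units; beyond the scatter) and a 4.0-fold higher number from compound 3 to compound 4 (0.60 log units; beyond the scatter) show, so a group on this aromatic carbon can push the number either way depending on what it carries. No measurement available here explains this reversal.

Still open, from the compounds shown here alone, is whether a plain methyl or a longer chain without nitrogen would behave like aminomethyl or like the benzyl-bearing groups. A carboxylic acid on the same carbon is equally unsettled.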